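Replacing dodecyl with 3,4-dimethoxyphenyl on the side chain

This account rests on a few compounds, and the source may have more. Where it says the series, first, only, none or still open, it means among the compounds named here.

Compounds in a functional assay on SK-BR-3 cells (Homo sapiens) for antiproliferative activity, read by MTT assay, with a stated time of 72 h; on this read-out lower numbers stand for stronger inhibition and higher numbers for weaker inhibition:
- compound 1 `C/C=C1/[C@H](O[C@@H]2O[C@H](CO)[C@@H](O)[C@H](O)[C@H]2O)OC=C(C(=O)OC)[C@H]1CC(=O)OCc1ccco1`: > 15000 nM (a limit)
- compound 2 `C/C=C1/[C@H](O[C@@H]2O[C@H](CO)[C@@H](O)[C@H](O)[C@H]2O)OC=C(C(=O)OC)[C@H]1CC(=O)OCCc1ccc2c(c1)OCCO2`: > 20000 nM (a limit)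
- compound 3 `C/C=C1/[C@H](O[C@@H]2O[C@H](CO)[C@@H](O)[C@H](O)[C@H]2O)OC=C(C(=O)OC)[C@H]1CC(=O)OCCCCCCCCCCCCCCC`: 1600 nM
- compound 4 `C/C=C1/[C@H](O[C@@H]2O[C@H](CO)[C@@H](O)[C@H](O)[C@H]2O)OC=C(C(=O)OC)[C@H]1CC(=O)OCCCc1ccc(OC)c(OC)c1`: not yet measured

Among the compounds with values here, compound 3 gives 1600 nM, the only true number in the set. The other two values are limits. Compound 4 differs from compound 3 as follows: 3,4-dimethoxyphenyl in place of dodecyl on a saturated chain carbon, three bonds along the chain from an oxygen next to a carbonyl group. In words, 3,4-dimethoxyphenyl stands in place of dodecyl on a saturated chain carbon, three bonds along the chain from an oxygen next to a carbonyl group.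

Within the data shown here, the one measured step is a step that the two limits leave unreadable from compound 1 to compound 2, so it offers no size to carry over. The guidance is indirect. Compound 4 loses the dodecyl of compound 3 and gains a ring, and ring-bearing side chains have so far returned only limits. Compound 1 stays at its limit of > 15000 nM. Compound 2 stays at its limit of > 20000 nM.

On that basis, the expected step is a 13-fold higher number from compound 3 to compound 4 (1.10 log units; beyond the scatter), towards weaker inhibition in this assay, and a report as a limit is likely. The estimate for compound 4 is 20000 nM, with an expected range of 7000 nM to 60000 nM.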

Compound 4, half-maximal inhibitory concentration: > 20000 nM
Compound 4: a limit, no number; the forecaster's own chance of this, stated with the estimate: 70%; the middle value sits exactly at the limit.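

In this assay, within the data shown here, 3,4-dimethoxyphenyl in place of dodecyl, on a saturated chain carbon three bonds along the chain from an oxygen next to a carbonyl group, gives an at least 12-fold higher number from compound 3 to compound 4 (1.09 log units; beyond the scatter), the first step with a readable size. In this assay, compound 4 gives > 20000 nM, which is a limit and not a number. The only true number therefore stays with the dodecyl side chain of compound 3, the steps among compounds 1, 2 and 4 cannot be read, and compound 4 shares its limit with compound 2: the limit of > 20000 nM in this assay, at which 2 of the 4 values shown sit.

The compounds shown do not separate the loss of dodecyl from the gain of the ring. An octyl chain, an unsubstituted phenyl or a dodecyl chain ending in a carboxylic acid at this place would begin to tell these apart.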